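The source may hold more compounds than are shown below. What is called first, only, known or untested is meant among the compounds shown, and "the series" means these compounds.

Measured so far in an assay on isolated protein for binding affinity to corticotropin-releasing factor receptor 1 (Rattus norvegicus); on this read-out lower numbers stand for stronger inhibition and higher numbers for weaker inhibition:

compound 1, `CCN(Cc1ccco1)c1cc(C)nc2c1NC(=O)CN2c1ccc(C(C)C)cc1Br`: 4.1 nM
compound 2, `CCCCN(CC)c1cc(C)nc2c1NC(=O)CN2c1ccc(OC)cc1C`: 0.92 nM
compound 3, `CCCCN(CC)c1cc(C)nc2c1NC(=O)CN2c1ccc(Cl)cc1Cl`: 0.49 nM

On these three numbers compound 2 stands second highest. Its nearest neighbour is compound 3: a 1.9-fold lower number from compound 2 to compound 3 (0.27 log units; within the scatter), a step that stays within the scatter, so the two are not distinguished. The furthest is compound 1, whose number stands above that of compound 2 by a gap beyond the scatter.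

The next compound in the series is compound 4, `CCN(CCCC#N)c1cc(C)nc2c1NC(=O)CN2c1ccc(OC)cc1C`. Relative to compound 2 the change is cyano in place of methyl on a saturated chain carbon, three bonds along the chain from a nitrogen on an aromatic ring. Among the compounds with values here, the only measured step available, from compound 2 to compound 3, alters the aryl group on the ring nitrogen and leaves the chain untouched, so it does not bear on this exchange; no measured pair tests cyano against methyl on the chain. Without a step on the chain, the series gives no direction, and the expectation defaults to a step close to the scatter, with the larger uncertainty on the side of a weaker number.

Compound 4 is therefore expected to give 1.5 nM in this assay, within 0.5 nM to 5 nM, the expected step from compound 2 being a 1.6-fold higher number from compound 2 to compound 4 (0.21 log units; within the scatter).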

Compound 4, half-maximal inhibitory concentration: 92 nM
For compound 4 the middle estimate is 61-fold (1.79 log units) below the measured one; measured number above the stated range.
By their numbers in this assay, from the lowest: compounds 3 and 2 (each within the scatter of the next); then compound 1; then compound 4.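

In this assay, the chain on the nitrogen on the aromatic ring proves far from neutral: butyl to 3-cyanopropyl, with nothing else altered, gives a 100-fold higher number from compound 2 to compound 4 (2.00 log units; beyond the scatter). Within the data shown here, the only earlier one-place step, a 1.9-fold lower number from compound 2 to compound 3 (0.27 log units; within the scatter), lay on the aryl group, so this is the first single change that moves the number beyond the scatter, and it sits on the chain alone. Nothing measured on the series bears on why the number rises so far.

The compounds shown do not settle whether the step belongs to the nitrile itself or to any replacement of the methyl at this chain end; a hydroxyl, an amine, a carboxylic acid or a longer chain such as pentyl at the same place would separate those two readings. Also open, going by these compounds, is whether the same exchange carries over to the 2,4-dichlorophenyl group of compound 3, and whether the size of the step changes when the nitrile sits closer along the chain, as in 2-cyanoethyl or cyanomethyl.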